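The source may report more compounds than this note shows. Statements on the series, on what has been measured and on what is new or still open speak of the compounds shown alone.

Compound 1 `COC(=O)N1N=C(c2ccccc2)NN=C1c1ccccc1`: in a functional assay on P388 cells (Mus musculus) for antiproliferative activity, read by MTT assay (a lower number here means a stronger inhibitor, a higher number a weaker inhibitor), compound 1 gives > 100000 nM, a limit of the assay.
Compound 2 `CCOC(=O)N1N=C(c2ccccc2)NN=C1c1ccccc1`: in this assay compound 2 gives > 100000 nM, a limit.
Compound 3 `CCCOC(=O)N1N=C(c2ccccc2)NN=C1c1ccccc1`: in this assay compound 3 gives > 100000 nM, a limit.

Compound 3 therefore stands at no number; all three values sit at the limit of > 100000 nM in this assay, at which 3 of the 3 values shown sit. The steps a step that the two limits leave unreadable from compound 1 to compound 2, a step that the two limits leave unreadable from compound 1 to compound 3 and a step that the two limits leave unreadable from compound 2 to compound 3 each lengthen the chain on the oxygen next to the carbonyl group, and none of them is readable in this assay.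

Compound 4 `CC(C)CCOC(=O)N1N=C(c2ccccc2)NN=C1c1ccccc1` continues the same chain: isopropyl in place of methyl on a saturated chain carbon, two bonds along the chain from an oxygen next to a carbonyl group. For the measured compounds named here, every step so far along this chain is unreadable, so no step beyond a limit is expected in this assay. Compound 4 is expected to sit at the same limit, estimated at 150000 nM, range 50000 nM to 500000 nM. The expected step that the limit leaves unreadable from compound 3 to compound 4 is thus no readable change.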

Compound 4, half-maximal inhibitory concentration: 24600 nM
Beside the measured number, compound 4's estimate is 6.1-fold (0.79 log units) above it, outside the stated range (below it).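

In this assay there is an at least 4.0-fold lower number from compound 3 to compound 4 (0.60 log units; beyond the scatter) with isopropyl in place of methyl on a saturated chain carbon, two bonds along the chain from an oxygen next to a carbonyl group, so this place can carry a readable change. Compound 4 also separates from the shorter chains, with an at least 4.0-fold lower number from compound 2 to compound 4 (0.60 log units; beyond the scatter) and an at least 4.0-fold lower number from compound 1 to compound 4 (0.60 log units; beyond the scatter) as the other readable steps. The steps among compound 1, compound 2 and compound 3 cannot be read: the limit of > 100000 nM in this assay, at which 3 of the 4 values shown sit.

Whether branching or added length matters stays open, since the straight pentyl chain is not among the compounds shown. As far as these compounds go, a longer chain or a terminal amine at this place also remains open.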